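Removing the tert-butylamino group on the shared core

The compounds below may be only part of what the source reports. "The series", "measured", "known", "first", "only" and "open" are said of these compounds alone.

The measured compounds and their values:
compound 1, `COc1ccc2c(c1)OC(c1cc(OC)c(OC)c(OC)c1)C(C(=O)NC(C)(C)C)=C2`, 28400 nM
compound 2, `COc1ccc2c(c1)OC(c1cc(OC)c(OC)c(OC)c1)C(C=O)=C2`, 13500 nM
compound 3, `COC(=O)C1=Cc2ccc(OC)cc2OC1c1cc(OC)c(OC)c(OC)c1`, 13800 nM

All three were tested in a functional assay for inhibition of nuclear factor NF-kappa-B complex (Homo sapiens); on this read-out higher numbers stand for weaker inhibition and lower numbers for stronger inhibition. Compound 1 gives the highest of the three numbers; its nearest neighbour is compound 3, and compound 2 lies a little further off, both of them beyond the scatter. The two measured steps away from compound 1 both concern the carbonyl carbon: a 2.1-fold lower number from compound 1 to compound 2 (0.32 log units; beyond the scatter), and a 2.1-fold lower number from compound 1 to compound 3 (0.31 log units; beyond the scatter). Between compound 2 and compound 3 there is no movement beyond the scatter: a 1.0-fold higher number from compound 2 to compound 3 (0.01 log units; within the scatter).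

Compound 4, `COc1ccc2c(c1)OC(c1cc(OC)c(OC)c(OC)c1)C(C(=O)O)=C2`, has not yet been measured in this assay. It differs from compound 1 in one place: hydroxy in place of (tert-butyl)amino on a carbonyl carbon. The two measured steps that replace the (tert-butyl)amino group, from compound 1 to compound 2 and from compound 1 to compound 3, each lowered the number modestly and by about the same amount, whatever entered. On that basis the step to compound 4 is expected to be modest and downward as well, with the hydroxy group behaving like the other small replacements; the expected step is a 1.6-fold lower number from compound 1 to compound 4 (0.20 log units; within the scatter). Compound 4 is therefore estimated at 18000 nM, with a range from 7000 nM to 45000 nM.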

Compound 4, half-maximal inhibitory concentration: > 50000 nM
Compound 4 ended at the assay's limit; the forecaster's own chance of this, stated with the estimate: 10%; middle value at least 2.7-fold (0.44 log units) from the limit.
By their numbers in this assay, from the lowest: compounds 2 and 3 (each within the scatter of the next); then compound 1. At a limit, above all of these: compound 4.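

In this assay compound 4 stands at a limit of the assay and not at a number: the limit of > 50000 nM in this assay, at which 1 of the 4 values shown sits.

Even so, this position proves less indifferent to what enters than the earlier compounds suggested, for hydroxy on the carbonyl carbon parts from the replacements that sat within the scatter of each other, with an at least 3.7-fold higher number from compound 2 to compound 4 (0.56 log units; beyond the scatter) and, for hydrogen in place of methyl on an oxygen next to a carbonyl group, an at least 3.6-fold higher number from compound 3 to compound 4 (0.55 log units; beyond the scatter). Replacing (tert-butyl)amino no longer lowers the number whatever enters, although an at least 1.7-fold higher number from compound 1 to compound 4 (0.24 log units; that floor lies within the scatter) has a floor that lies within the scatter, so compound 4 cannot yet be placed beyond the scatter from compound 1.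

As far as these compounds go, how far the number of compound 4 lies past the limit remains open. Also open, from the compounds shown here alone, is whether ethoxy on the carbonyl carbon would follow methoxy, and whether a plain amino group or a methylamino group there would stay with (tert-butyl)amino or move elsewhere.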